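Solubility in the quinolinyl azetidine series: carbamate-piperidinyl analogue

A few compounds are considered here, and "the series" means these few. Any claim that something is new, unique, unknown or untested is made for them only; others in the source may bear on it.

Measured compounds in a physicochemical assay for solubility, in phosphate buffer, at pH 7.4; on this read-out lower numbers stand for lower solubility and higher numbers for higher solubility:
compound 1 `OCC1CCN(c2nccnc2OC2CN(c3ccc4ccccc4n3)C2)C1` gives 167000 nM
compound 2 `COCC1CCN(c2nccnc2OC2CN(c3ccc4ccccc4n3)C2)CC1` gives 53000 nM
compound 3 `Cc1ccc(-c2nccnc2OC2CN(c3ccc4ccccc4n3)C2)cc1` gives < 1000 nM

Compound 1 heads the measured set in this assay. The step of a 3.2-fold lower number from compound 1 to compound 2 (0.50 log units; beyond the scatter) is modest. For the measured compounds named here, compound 3 sits at a limit of this assay rather than at a number; it is the one value resting on (the limit of < 1000 nM in this assay, at which 1 of the 3 values shown sits). The steps of an at least 160-fold lower number from compound 1 to compound 3 (2.22 log units; beyond the scatter) and an at least 53-fold lower number from compound 2 to compound 3 (1.72 log units; beyond the scatter) are the large ones in the set, and both end at that limit.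

Compound 4 `COC(=O)N1CCC(c2nccnc2OC2CN(c3ccc4ccccc4n3)C2)CC1` remains to be measured. Its change from compound 3 is 1-(methoxycarbonyl)piperidin-4-yl in place of 4-methylphenyl on an aromatic carbon. Going by the values given here, the steps that bear on it are the two large ones into compound 3, in which 4-methylphenyl displaced a saturated nitrogen-containing ring; compound 4 reverses that direction by bringing back a six-membered non-aromatic ring with 1 hetero atom and 2 hydrogen-bond acceptors, though attached through carbon rather than nitrogen and without a hydroxymethyl or methoxymethyl chain. On this basis a large step upward in this assay is expected for compound 4, of about an at least 20-fold higher number from compound 3 to compound 4 (1.30 log units; beyond the scatter). The estimate for compound 4 is 20000 nM, with a range from 3000 nM to 100000 nM; the compound 3 limit keeps the lower end of that range uncertain.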

Compound 4, solubility: 138000 nM
The estimate for compound 4 lay 6.9-fold (0.84 log units) below the measured number; measured number above the stated range.
By their numbers in this assay, from the lowest: compound 2; then compounds 4 and 1 (each within the scatter of the next). At a limit, below all of these: compound 3.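

Compound 4 shows that, on this aromatic carbon next to the ring nitrogen, a saturated ring attached through carbon and without a hydroxymethyl or methoxymethyl chain still stands far from 4-methylphenyl in this assay, with an at least 130-fold higher number from compound 3 to compound 4 (2.13 log units; beyond the scatter). Compared with the two rings attached through nitrogen, 1-(methoxycarbonyl)piperidin-4-yl gives a 2.6-fold higher number from compound 2 to compound 4 (0.42 log units; beyond the scatter), while a 1.2-fold lower number from compound 1 to compound 4 (0.08 log units; within the scatter) leaves compound 4 and compound 1 indistinguishable in this assay, so attachment through nitrogen is not required for a number in this range among the compounds shown. Compound 3 stands at a limit rather than at a number, so the step from it gives a minimum size only: the limit of < 1000 nM in this assay, at which 1 of the 4 values shown sits.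

On these data alone, it remains open whether the higher number in compound 4 goes with the saturated ring alone or with the methoxycarbonyl group on its nitrogen. A cyclohexyl ring, an unsubstituted piperidin-4-yl or an acetyl group on the piperidine nitrogen at this position would separate those two readings, and a phenyl ring carrying a carboxylic acid or an amine would test whether the aromatic ring itself must be replaced.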